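The compounds below may be only part of what the source reports. "The series", "measured", "known", "first", "only" and "open" are said of these compounds alone.

Working notes on the series. Three compounds have numbers in a functional assay on cells for antagonist activity at Free fatty acid receptor 1 (Homo sapiens), read by TR-FRET and inositol phosphate accumulation, with a stated time of 2 h; on this read-out lower numbers stand for stronger inhibition and higher numbers for weaker inhibition: compound 1 `Cc1cc(COc2ccc(Cl)cc2)nc(-c2ccccn2)n1` gives 251 nM, compound 2 `Cc1cc(COc2cccc(F)c2)nc(-c2ccccn2)n1` gives 794 nM, and compound 3 `Cc1cc(COc2ccc(F)cc2)nc(-c2ccccn2)n1` gives 631 nM. Compound 3 stands second highest of the three; its nearest neighbour is compound 2, and the step of a 1.3-fold lower number from compound 2 to compound 3 (0.10 log units; within the scatter) lies within the scatter. The step of a 2.5-fold higher number from compound 1 to compound 3 (0.40 log units; beyond the scatter) is the only one beyond the scatter that touches compound 3.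

Compound 4 `Cc1cc(COc2ccc(F)c(F)c2)nc(-c2ccccn2)n1` is the next step: fluoro in place of hydrogen on an aromatic carbon. Within the data shown here, no measured pair shows a hydrogen replaced by fluoro, so the bearing steps are indirect. The step of a 2.5-fold higher number from compound 1 to compound 3 (0.40 log units; beyond the scatter) shows that exchanging the halogen on that ring moved the number by a modest amount, while the step of a 1.3-fold lower number from compound 2 to compound 3 (0.10 log units; within the scatter) shows that moving a single fluoro on the ring changed little. A second fluoro is therefore expected to give at most a modest shift in this assay, more likely toward a lower number. The estimated step is a 1.4-fold lower number from compound 3 to compound 4 (0.15 log units; within the scatter). Compound 4 is expected to give 450 nM, with a range from 200 nM to 1100 nM.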

Compound 4, half-maximal inhibitory concentration: 501 nM
Compound 4: the middle estimate sits 1.1-fold (0.05 log units) below what was measured; the range from low to high includes it.
By their numbers in this assay, from the lowest: compounds 1, 4, 3 and 2 (each within the scatter of the next, the first and the last beyond it).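

In this assay, among these compounds, these are the first measured pairs in which fluoro replaces hydrogen on an aromatic carbon, here ortho to a fluoro group and meta to a large group. Both readings of the change stay within the scatter: a 1.3-fold lower number from compound 3 to compound 4 (0.10 log units; within the scatter) and a 1.6-fold lower number from compound 2 to compound 4 (0.20 log units; within the scatter), so neither pair separates a second fluoro at this position from hydrogen, whichever single fluoro is the starting point. No measurement available here accounts for this result.

From the compounds shown here alone, it remains open whether a larger group on this same aromatic carbon, such as chloro, methoxy or an amine, would move the number beyond the scatter. Going by these compounds, it is also open whether a second fluoro would behave the same way alongside the chloro of compound 1.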